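The compounds below may be only part of what the source reports. "The series", "measured", "known", "first", "only" and "open" are said of these compounds alone.

Compound 1 `O=C(NCN1CCC(c2cccc[n+]2[O-])CC1)c1cnccc1Cl` is the weakest of three compounds examined in a functional assay on HEK293 cells for agonist activity at D(4) dopamine receptor (Homo sapiens), read by FLIPR (on this read-out lower numbers stand for an effect already at smaller amounts and higher numbers for an effect only at larger amounts of compound), where compound 1 gives 1290 nM. Compound 2 `O=C(CN1CCC(c2cccc[n+]2[O-])CC1)Nc1cccc(Cl)c1` gives 62 nM and compound 3 `[O-][n+]1ccccc1C1CCN(Cc2nc3ccccc3[nH]2)CC1` gives 54 nM; both sit well below compound 1, by more than the usual scatter. Compound 4 `Cc1cc(C(=O)NCN2CCC(c3cccc[n+]3[O-])CC2)ccc1Cl` has not yet been measured. It differs from compound 1 in one place: 4-chloro-3-methylphenyl in place of 4-chloropyridin-3-yl on a carbonyl carbon. Going by the values given here, no measured pair shows this change, so the size of the step is a matter of expectation. A moderate move toward a lower number seems plausible, and the step from compound 1 to compound 4 in this assay is estimated at a 2.6-fold lower number from compound 1 to compound 4 (0.41 log units; beyond the scatter). Compound 4 is accordingly expected to give about 500 nM, with a likely range from 120 nM to 2500 nM.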

Compound 4, half-maximal effective concentration: 2460 nM
Compound 4: the middle estimate sits 4.9-fold (0.69 log units) below what was measured; the range from low to high includes it.
By their numbers in this assay, from the lowest: compounds 3 and 2 (each within the scatter of the next); then compounds 1 and 4 (each within the scatter of the next).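

In this assay, replacing 4-chloropyridin-3-yl with 4-chloro-3-methylphenyl on the carbonyl carbon gives a 1.9-fold higher number from compound 1 to compound 4 (0.28 log units; within the scatter) and so does not separate the two compounds. At this position, an aromatic ring of carbon only with an added methyl group therefore reads the same as the ring with one hetero atom. Nothing available gives a reason for this result. Going by these compounds, the ring atom and the methyl group differ together here, so their separate contributions remain open. Also open, on these data alone, is how an amine or a carboxylic acid on this ring would read.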